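A few compounds are considered here, and "the series" means these few. Any claim that something is new, unique, unknown or untested is made for them only; others in the source may bear on it.

The series is built around a shared amide core carrying a biaryl group on the amide nitrogen. Compound 1, `Cc1ccc2nc(C(=O)Nc3c(F)cc(-c4cccc(F)c4)cc3F)c(C)c(O)c2c1`, gives 19.2% in a functional assay on Hep 3B2 cells (Homo sapiens) for antiproliferative activity, read by MTT assay, with a stated time of 24 h, tested at 3.7 ug/mL; on this read-out higher numbers stand for a stronger effect at the one concentration tested and lower numbers for a weaker effect. Compound 2, `COc1ccc2nc(C(=O)Nc3ccc(-c4ccccc4)cc3)c(C)c(O)c2c1`, gives 23.5% in this assay. Of the two numbers recorded, the figure for compound 2 is the one that sits nominally higher, but its distance from compound 1 falls inside the usual scatter of repeated measurements, so the two compounds cannot be told apart on this read-out.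

Compound 3, `Cc1c(C(=O)Nc2ccc(-c3ccccc3)cc2)nc2ccccc2c1O`, has not yet been measured. Relative to compound 2 the change is a single one: hydrogen in place of methoxy on an aromatic carbon. Among the measured compounds shown here, nothing measured so far isolates the effect of this change, since no two measured compounds differ only at this point. Without such a reference, the expected step from compound 2 to compound 3 is estimated as small, a number 4.5 percentage points lower from compound 2 to compound 3 (within the scatter), and not beyond the scatter in either direction. Compound 3 is therefore expected to give about 19% in this assay, with an estimated range from 6% to 32%.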

Compound 3, a percentage reported as inhibition, at one concentration (the size of the read-out at that concentration, not a potency): 21.5%
Compound 3: middle estimate off by 2.5 percentage points, on the low side; measured number inside the range.
By their numbers in this assay, from the lowest: compounds 1, 3 and 2 (each within the scatter of the next).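

Among the compounds shown here, the pair of compound 2 and compound 3 is the first to differ in one place only, so the change can now be read directly: in this assay, hydrogen in place of methoxy on an aromatic carbon gives a number 2 percentage points lower from compound 2 to compound 3 (within the scatter). At this position, on the six-membered aromatic ring of carbon only that is part of the fused system, the loss of the methoxy group with its 2 heavy atoms and 1 hydrogen-bond acceptor leaves no difference that this read-out can resolve at the one concentration tested, and the group is thus shown not to be needed to keep the number where it stands. No measurement shown here speaks to why the two compounds read alike.

The compounds shown leave open how an amine, a carboxylic acid or a longer alkoxy chain on this same aromatic carbon would read, since methoxy and hydrogen are the only two groups compared there. They also leave open whether the same replacement would give so small a step with a different group on the amide nitrogen, as compound 1 differs from the other two compounds in more than one place.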